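Imine analogues of an aminothiophene series: cytotoxicity notes

The source may report more compounds than this note shows. Statements on the series, on what has been measured and on what is new or still open speak of the compounds shown alone.

Measured so far:
compound 1 `Nc1sc2c(c1-c1nc3ccccc3s1)CCCC2` — 253 ug/mL
compound 2 `Clc1ccc(/C=N/c2sc3c(c2-c2nc4ccccc4s2)CCC3)cc1` — 342 ug/mL
compound 3 `Clc1ccc(/C=N/c2sc3c(c2-c2nc4ccccc4s2)CCC3)c(Cl)c1` — 160 ug/mL

In an ADME assay on cells (Rhabdomyosarcoma cell, Homo sapiens) for cytotoxicity, read by MTT assay, with a stated time of 72 h (a higher number here means that more compound is tolerated, a lower number that less compound is tolerated), compound 1 stands second highest of the three numbers, within the scatter of both compound 2 and compound 3. Going by the values given here, the only measured step, a 2.1-fold lower number from compound 2 to compound 3 (0.33 log units; beyond the scatter), concerns chloro in place of hydrogen on an aromatic carbon and is modest. Among the compounds with values here, compound 4 `Clc1ccccc1/C=N/c1sc2c(c1-c1nc3ccccc3s1)CCCC2` differs from compound 1 by a group of 9 heavy atoms (7 carbon, 1 nitrogen, 1 chlorine; one six-membered aromatic ring of carbon only) in place of one nitrogen atom, on an aromatic carbon; no measured step covers an amino replaced by this kind of group, so that step carries no direct precedent. Compound 2 and compound 3, which already bear such groups, lie within the scatter of compound 1, so compound 4 is expected to show no step beyond the scatter, a 1.0-fold higher number from compound 1 to compound 4 (0.01 log units; within the scatter), and is estimated at 260 ug/mL with a range of 130 ug/mL to 520 ug/mL.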

Compound 4, half-maximal cytotoxic concentration: 332 ug/mL
Estimate against measurement, compound 4: 1.3-fold (0.11 log units) below; the range from low to high includes it.
By their numbers in this assay, from the lowest: compounds 3, 1, 4 and 2 (each within the scatter of the next, the first and the last beyond it).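

In this assay, going by these compounds alone, the exchange of amino for the group of 9 heavy atoms, on the aromatic carbon next to the ring sulfur, gives a 1.3-fold higher number from compound 1 to compound 4 (0.12 log units; within the scatter) and is the first direct reading of a change at this place on the core of compound 1. The free amino, with its hydrogen-bond donor, is therefore not needed to keep the number within the scatter. No available evidence bears on this result.

Open, going by these compounds, is whether the chloro contributes anything here. A plain phenyl imine, or a methoxy or carboxylic acid on that ring, would test this.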